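From butyl to 3-methylphenyl on an aromatic nitrogen

A few compounds are considered here, and "the series" means these few. Any claim that something is new, unique, unknown or untested is made for them only; others in the source may bear on it.

In a functional assay on HCT-15 cells (Homo sapiens) for antiproliferative activity, read by MTT assay, with a stated time of 72 h (on this read-out lower numbers stand for stronger inhibition and higher numbers for weaker inhibition), compound 1 `CCCCn1ccnc1-c1cc(OC)c(OC)c(OC)c1` gives > 100000 nM as a limit of the assay and not a number. Compound 1 therefore stands at the limit of > 100000 nM in this assay, at which 1 of the 2 values shown sits, and offers no exact starting point for comparison.

Among the compounds with values here, compound 2 `COc1cc(-c2nccn2-c2ccc3[nH]ccc3c2)cc(OC)c1OC` gives a measured number in this assay of 4600 nM and is the only exact reference so far.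

Compound 3 `COc1cc(-c2nccn2-c2cccc(C)c2)cc(OC)c1OC` is the next compound to be tested. It carries 3-methylphenyl in place of butyl on an aromatic nitrogen of a five-membered aromatic ring with 2 nitrogen, and the counted difference is 3-methylphenyl in place of butyl on an aromatic nitrogen for this exchange.

Within the data shown here, no measured step between two compounds is available to calibrate this change. The expectation of a gain rests only on compound 2 at 4600 nM as evidence that a measurable number is reachable in the series.

Expected is an at least 11-fold lower number from compound 1 to compound 3 (1.04 log units; beyond the scatter) in the direction of stronger inhibition and beyond the scatter.

For compound 3 the estimated value is 9000 nM with an expected range from 1500 nM to 60000 nM in this assay on this read-out.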

Compound 3, half-maximal inhibitory concentration: 1600 nM
Compound 3: middle estimate off by 5.6-fold (0.75 log units), on the high side; the measured number falls inside the stated range.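

In this assay, within the data shown here, 3-methylphenyl in place of butyl on the aromatic nitrogen gives an at least 62-fold lower number from compound 1 to compound 3 (1.79 log units; beyond the scatter), the first step that can be read at this position, and it leads from a compound without an exact number to one with a measured value. On these data alone, the value of compound 1, > 100000 nM, is a limit of the assay and not a number, so this step marks only a minimum and its full size stays unknown: the limit of > 100000 nM in this assay, at which 1 of the 3 values shown sits. Compound 3 gives 1600 nM and compound 2 gives 4600 nM, so the two compounds with a ring-bearing group on this nitrogen both reach measured numbers, while compound 1 with butyl does not.

The compounds shown do not separate the contribution of the aromatic ring from that of its methyl group or of the larger carbon count in the group that enters. A plain phenyl on the same nitrogen would isolate the methyl group, while a benzyl group or a hexyl chain would test whether a comparable carbon count without a directly attached aromatic ring also gives a measurable number.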